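Trimming the biaryl to a single trifluoromethoxy group

The source may hold more compounds than are shown below. What is called first, only, known or untested is meant among the compounds shown, and "the series" means these compounds.

Of the compounds shown here, two have been measured in an assay on isolated protein for inhibition of 2-Hydroxyacid oxidase 2 (Rattus norvegicus) (a lower number here means a stronger inhibitor, a higher number a weaker inhibitor), so far. Compound 1 `Cc1n[nH]c(C(=O)O)c1Cc1cccc(-c2ccc(OC(F)(F)F)cc2)c1` gives 300 nM in this assay. Compound 2 `Cc1n[nH]c(C(=O)O)c1Cc1cccc(-c2ccc(C#N)cc2)c1` gives 300 nM in this assay, and the step of no change at the digits printed from compound 1 to compound 2 (within the scatter) shows that swapping the distal group on the outer ring made no difference within the scatter. Compound 2 therefore stands level with compound 1. Compound 3 `Cc1n[nH]c(C(=O)O)c1Cc1cccc(OC(F)(F)F)c1` differs from compound 2 by a larger change: trifluoromethoxy in place of 4-cyanophenyl on an aromatic carbon. For the measured compounds named here, no measured step bears on removing the outer ring itself; the only known step, no change at the digits printed from compound 1 to compound 2 (within the scatter), concerns just the group on that ring. Without a measured precedent, the loss of a whole aromatic ring is expected to weaken inhibition, and the expected step is a 10-fold higher number from compound 2 to compound 3 (1.00 log units; beyond the scatter). Compound 3 is estimated at 3000 nM in this assay, with a range from 800 nM to 15000 nM.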

Compound 3, half-maximal inhibitory concentration: 700 nM
Beside the measured number, compound 3's estimate is 4.3-fold (0.63 log units) above it; measured number below the stated range.
By their numbers in this assay, from the lowest: compounds 1 and 2 (each within the scatter of the next); then compound 3.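

Compound 3 shows that the outer aromatic ring is not required for inhibition at this level. In this assay, replacing the whole 4-cyanophenyl group with trifluoromethoxy gives a 2.3-fold higher number from compound 2 to compound 3 (0.37 log units; beyond the scatter), a loss that is real but modest even though the group shrinks from 8 heavy atoms to 5 and no longer holds a ring. No available evidence accounts for how small this loss is.

The compounds shown leave open whether the remaining inhibition depends on trifluoromethoxy itself or would survive with a different small group in this place, such as an amine, a methoxy group or a bare hydrogen. They also leave open whether a longer chain, such as a butyl group, could recover the difference without an aromatic ring.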